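The source may hold more compounds than are shown below. What is called first, only, known or untested is meant among the compounds shown, and "the series" means these compounds.

Measured so far in a functional assay on Caco-2 cells (Homo sapiens), read by fluorescence, tested at 1 uM; a lower number here means a stronger effect, a higher number a weaker effect of the compound at the concentration tested:

Compound 1 `C=CCNC(=C\C(=O)/C=C/c1ccc(O)c(OC)c1)/C=C/c1ccc(O)c(OC)c1`: 89%
Compound 2 `COc1cc(/C=C/C(=O)/C=C(/C=C/c2ccc(OC(C)=O)c(OC)c2)NCC(C)C)ccc1OC(C)=O`: 96%

In this assay compound 1 gives 89%, the lower of the two numbers. Compound 2 gives 96%, which lies within the usual scatter of compound 1, so the two show no real difference at this concentration.

Compound 3 `CCCCNC(=C\C(=O)/C=C/c1ccc(O)c(OC)c1)/C=C/c1ccc(O)c(OC)c1` differs from compound 1 in one place: propyl in place of vinyl on a saturated chain carbon bound to an amine nitrogen. Within the data shown here, no measured pair shows this change, so its effect is unknown here. The step of a number 1 percentage points higher from compound 1 to compound 3 (within the scatter) is expected to be small, not beyond the scatter. Compound 3 is therefore expected to give about 90% in this assay, between 78% and 100%.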

Compound 3, a percentage reported as activity, at one concentration (the size of the read-out at that concentration, not a potency): 91%
For compound 3 the middle estimate is 1 percentage points below the measured one, and the stated range covers the measured number.
By their numbers in this assay, from the lowest: compounds 1, 3 and 2 (each within the scatter of the next).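

Replacing allylamino with butylamino gives, in this assay, a number 2 percentage points higher from compound 1 to compound 3 (within the scatter). At this position, then, the vinyl end with its double bond and the fully saturated propyl cannot be told apart at this concentration, a comparison the first two compounds, which differ in more than one place, could not offer. Nothing measured here offers an explanation for this result.

Still open, as far as these compounds go, is whether a longer chain, a phenyl ring or a carboxylic acid on this saturated chain carbon would move the number beyond the scatter.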